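Nitro for bromo on the sulfonyl aryl

The compounds below may be only part of what the source reports. "The series", "measured", "known", "first", "only" and "open" are said of these compounds alone.

The shared core is that of compound 1 `CCOC(=O)c1oc2ccc(NS(=O)(=O)c3ccc(F)cc3)cc2c1C`. In a functional assay on HCT-116 cells (Homo sapiens) for inhibition, read by MTT assay, with a stated time of 72 h (a higher number here means a weaker inhibitor, a lower number a stronger inhibitor), compound 1 gives only a limit, > 40000 nM. Compound 2 `CCOC(=O)c1oc2ccc(N(Cc3ccccc3)S(=O)(=O)c3ccc(Br)cc3)cc2c1C`, carrying a benzyl on the sulfonamide nitrogen, gives 8700 nM in this assay. Compound 3 `CCOC(=O)c1oc2ccc(N(Cc3ccccc3)S(=O)(=O)c3ccccc3Br)cc2c1C` gives only a limit in this assay, > 40000 nM. For the measured compounds named here, compound 2 therefore stands as the sole number in this assay; the remaining two entries are the limit of > 40000 nM in this assay, at which 2 of the 3 values shown sit. Going by the values given here, the one measured step, an at least 4.5-fold higher number from compound 2 to compound 3 (0.66 log units; beyond the scatter), moves the bromo to another position on the sulfonyl aryl rather than exchanging it for a different group.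

Compound 4 `CCOC(=O)c1oc2ccc(N(Cc3ccccc3)S(=O)(=O)c3ccc([N+](=O)[O-])cc3)cc2c1C` differs from compound 2 by nitro in place of bromo on an aromatic carbon. Among the compounds with values here, no measured step exchanges the substituent on the sulfonyl aryl, so the swap has no direct precedent; the positional step shows only that this aryl is sensitive to alteration, which is taken as a caution. The step from compound 2 to compound 4 is expected to be a 1.1-fold higher number from compound 2 to compound 4 (0.06 log units; within the scatter), within the scatter, with a real chance of a limit. Compound 4 is estimated at 10000 nM in this assay, between 3500 nM and 35000 nM.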

Compound 4, half-maximal inhibitory concentration: > 40000 nM
Compound 4: no number, only a limit (the forecaster's own chance of this, stated with the estimate: 25%); at least 4.0-fold (0.60 log units) between middle value and limit.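

Unlike the earlier positional step, this result exchanges the group itself at the place on the sulfonyl aryl that is para to a large group: in this assay, 4-nitrophenyl in place of 4-bromophenyl gives an at least 4.5-fold higher number from compound 2 to compound 4 (0.66 log units; beyond the scatter). Two different single changes to the 4-bromophenyl of compound 2 now cost the measurable number, the other being an at least 4.5-fold higher number from compound 2 to compound 3 (0.66 log units; beyond the scatter). For the compounds shown here, compound 3 and compound 4 both stand as limits, so the step between them cannot be read, and compound 2 remains the only compound with a number: the limit of > 40000 nM in this assay, at which 3 of the 4 values shown sit.

With only bromo and nitro shown at this place, what an amine or a carboxylic acid there would give stays open. Also open, on these data alone, is whether chloro or methyl would keep a readable number in this assay.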